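A Benzyl Group Replaces Cyclopentyl on Sulfur

The compounds below may be only part of what the source reports. "The series", "measured", "known", "first", "only" and "open" are said of these compounds alone.

Compound 3 `CC(C(=O)NCc1ccc(C(C)(C)C)nc1SC1CCCC1)c1ccc(NS(C)(=O)=O)c(F)c1` gives 2.5 nM in an assay on cells for antagonist activity at transient receptor potential cation channel subfamily V member 1 (Homo sapiens), read by FLIPR and calcium flux, with a stated time of 6 min (a lower number here means a stronger inhibitor, a higher number a weaker inhibitor), the highest of the three numbers; compound 1 `CC(C(=O)NCc1ccc(C(C)(C)C)nc1N1CCCCCC1)c1ccc(NS(C)(=O)=O)c(F)c1` gives 0.9 nM and compound 2 `CCCCCCSc1nc(C(C)(C)C)ccc1CNC(=O)C(C)c1ccc(NS(C)(=O)=O)c(F)c1` gives 1.5 nM in this assay. From compound 1 the steps ran a 1.7-fold higher number from compound 1 to compound 2 (0.22 log units; within the scatter) and a 2.8-fold higher number from compound 1 to compound 3 (0.44 log units; beyond the scatter). Compound 4 `CC(C(=O)NCc1ccc(C(C)(C)C)nc1SCc1ccccc1Cl)c1ccc(NS(C)(=O)=O)c(F)c1` differs from compound 3 by 2-chlorobenzyl in place of cyclopentyl on a sulfur. Among the compounds with values here, the one measured change at that same sulfur, a 1.7-fold higher number from compound 2 to compound 3 (0.22 log units; within the scatter), barely moved the number, and nothing measured shows a benzyl group there. On that basis compound 4 is expected to stay close, with a step of no change at the digits printed from compound 3 to compound 4 (within the scatter), not beyond the scatter. Compound 4 is estimated at 2.5 nM, within a range from 0.8 nM to 8 nM.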

Compound 4, inhibition constant: 3.8 nM
For compound 4 the middle estimate is 1.5-fold (0.18 log units) below the measured one, within the range that was stated.
By their numbers in this assay, from the lowest: compounds 1, 2, 3 and 4 (each within the scatter of the next, the first and the last beyond it).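

In this assay an aromatic ring is accepted on this sulfur: 2-chlorobenzyl in place of cyclopentyl gives a 1.5-fold higher number from compound 3 to compound 4 (0.18 log units; within the scatter) and so stays level with the cyclopentyl compound. A loss beyond the scatter appears only in the wider comparisons, with a 2.5-fold higher number from compound 2 to compound 4 (0.40 log units; beyond the scatter) when 2-chlorobenzyl is set against hexyl, and a 4.2-fold higher number from compound 1 to compound 4 (0.63 log units; beyond the scatter) when (2-chlorobenzyl)sulfanyl is set against azepan-1-yl. No measurement available here explains these differences.

The compounds shown leave open what the chlorine contributes, since plain benzyl does not appear among them. They also leave open how a carboxylic acid or an amine at the end of the chain on this sulfur would fare.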